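Methyl to Dimethylamino: Expected Potency of Compound 4

This account rests on a few compounds, and the source may have more. Where it says the series, first, only, none or still open, it means among the compounds named here.

Of the compounds shown here, three sharing one core have been measured in a functional assay for inhibition, with Homo sapiens as the target; a higher number here means a weaker inhibitor, a lower number a stronger inhibitor. Compound 1 `Cc1cccc(Nc2nccc(-c3cccs3)n2)c1` gives 300 nM, the lowest of the three numbers. Compound 2 `Cc1cccc(Nc2nccc(-c3cc(C)oc3C)n2)c1` gives 28500 nM, and compound 3 `CNc1ccc(Nc2nccc(-c3cccnc3)n2)cc1` gives 2100 nM. Going by the values given here, the only single-change step among them, a 95-fold higher number from compound 1 to compound 2 (1.98 log units; beyond the scatter), concerns the thiophen-2-yl group on the far side of the core, not the substituent on the six-membered aromatic ring of carbon only.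

Compound 4 `CN(C)c1cccc(Nc2nccc(-c3cccs3)n2)c1` differs from compound 1 by the change (dimethylamino in place of methyl on an aromatic carbon). Among the compounds with values here, no measured step bears directly on this change: compound 3 differs from compound 1 in more than one place, so its value cannot be read as the effect of a single change. Within the data shown here, with no guiding step, the expectation for compound 4 is a small step, a 1.5-fold higher number from compound 1 to compound 4 (0.18 log units; within the scatter), toward a slightly higher number, likely within the scatter of repeated measurements. Compound 4 is therefore estimated at 450 nM, in a range from 120 nM to 1800 nM.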

Compound 4, half-maximal inhibitory concentration: 2400 nM
Beside the measured number, compound 4's estimate is 5.3-fold (0.73 log units) below it; the measured number lies above the stated range.
By their numbers in this assay, from the lowest: compound 1; then compounds 3 and 4 (each within the scatter of the next); then compound 2.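

In this assay, putting dimethylamino in place of methyl on the six-membered aromatic ring of carbon only gives an 8.0-fold higher number from compound 1 to compound 4 (0.90 log units; beyond the scatter), which means a weaker inhibitor. Going by these compounds alone, this is the first single change read at this position, as the earlier step concerned only the thiophen-2-yl group, and it shows that this position does not accept every substituent equally. Nothing at hand explains why the inhibitor weakens with this change.

The compounds shown compare only methyl and dimethylamino here, so it remains open whether a simple amine, a methoxy group or a chlorine atom in the same place would stay close to compound 1. As far as these compounds go, it also remains open whether the step from methyl to dimethylamino would be of similar size with a group other than thiophen-2-yl on the shared core.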